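From Carboxy to (Dimethylamino)methyl: Estimating Compound 4

The source may report more compounds than this note shows. Statements on the series, on what has been measured and on what is new or still open speak of the compounds shown alone.

Compound 1 `CC(=O)NCC[C@@H]1C[C@@H](c2ccc(F)c(F)c2)[C@H](NC(=O)c2cc(-c3c(Cl)cnn3C)c(Cl)o2)CN1` — 920 nM
Compound 2 `Cn1ncc(Cl)c1-c1cc(C(=O)N[C@@H]2CN[C@H](CC(=O)O)C[C@H]2c2ccc(Cl)c(Cl)c2)oc1Cl` — 4020 nM
Compound 3 `CC(=O)OCC[C@@H]1C[C@@H](c2ccc(F)c(F)c2)[C@H](NC(=O)c2cc(-c3c(Cl)cnn3C)c(Cl)o2)CN1` — 690 nM

In a functional assay on HCT-116 cells (Homo sapiens) for antiproliferative activity, read by sulforhodamine B assay, with a stated time of 72 h (on this read-out lower numbers stand for stronger inhibition and higher numbers for weaker inhibition), compound 2 gives the highest of the three numbers, with compound 1 and compound 3 both lower by margins beyond the scatter. Compound 4 `CN(C)CC[C@@H]1C[C@@H](c2ccc(Cl)c(Cl)c2)[C@H](NC(=O)c2cc(-c3c(Cl)cnn3C)c(Cl)o2)CN1` differs from compound 2 by (dimethylamino)methyl in place of carboxy on a saturated chain carbon bound to a saturated ring carbon. Going by the values given here, the only measured step, a 1.3-fold lower number from compound 1 to compound 3 (0.12 log units; within the scatter), changes the same chain one bond further out and stays within the scatter, so it bears on this change only loosely; no measured pair exchanges carboxy for an amine, and compound 4 also carries the dichlorophenyl of compound 2 rather than the difluorophenyl of compound 1 and compound 3. A move toward lower numbers is expected, but uncertainty is wide. Compound 4 is therefore estimated at 700 nM, between 200 nM and 2500 nM, an expected step of a 5.7-fold lower number from compound 2 to compound 4 (0.76 log units; beyond the scatter).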

Compound 4, half-maximal inhibitory concentration: 1710 nM
Beside the measured number, compound 4's estimate is 2.4-fold (0.39 log units) below it; the measured number falls inside the stated range.
By their numbers in this assay, from the lowest: compounds 3, 1 and 4 (each within the scatter of the next, the first and the last beyond it); then compound 2.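

In this assay, (dimethylamino)methyl in place of carboxy on a saturated chain carbon bound to a saturated ring carbon gives a 2.4-fold lower number from compound 2 to compound 4 (0.37 log units; beyond the scatter), a modest change, but the first on this chain to go beyond the scatter. With the dichlorophenyl held constant, the carboxy proves not to be required for the activity of compound 2. No available data explain the size of this step.

On these data alone, it remains open whether the gain comes from losing the carboxylic acid or from adding the amine; a primary amine or a carboxamide on this chain could separate the two. As far as these compounds go, how the dimethylamino chain behaves with the difluorophenyl of compound 1 and compound 3 also remains open.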